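The source may report more compounds than this note shows. Statements on the series, on what has been measured and on what is new or still open speak of the compounds shown alone.

Measured compounds:
Compound 1, `COc1cccc(/C=C2\CCC/C(=C\c3cccc(Br)c3)C2=O)c1OC`, in a functional assay on HT-1080 cells (Homo sapiens) for cytotoxicity, read by MTT assay, with a stated time of 72 h (on this read-out lower numbers stand for stronger inhibition and higher numbers for weaker inhibition), gives 12200 nM.
Compound 2, `COc1cccc(/C=C2\CCC/C(=C\c3ccc(Br)cc3)C2=O)c1OC`, in this assay gives 13700 nM.
Compound 3, `COc1ccc(/C=C2\CCC/C(=C\c3cccc(Br)c3)C2=O)cc1OC`, in this assay gives 5200 nM.

Compound 3 is the most potent of the three, since its steps to compound 1 and to compound 2 both lie beyond the scatter. Compound 3 and compound 1 have different cores; the difference between the two cores is not broken down here. Compound 2 arises from compound 1 by the change (4-bromophenyl in place of 3-bromophenyl on a double-bonded chain carbon bound to a double-bonded ring carbon), which gave a 1.1-fold higher number from compound 1 to compound 2 (0.05 log units; within the scatter). Compound 4, `COc1ccc(/C=C2\CCC/C(=C\c3ccc(Br)cc3)C2=O)cc1OC`, is not yet measured; it arises from compound 3 by the same change, (4-bromophenyl in place of 3-bromophenyl on a double-bonded chain carbon bound to a double-bonded ring carbon). Because the earlier step of a 1.1-fold higher number from compound 1 to compound 2 (0.05 log units; within the scatter) stayed within the scatter, a step of similar size is expected here: a 1.1-fold higher number from compound 3 to compound 4 (0.05 log units; within the scatter). Compound 4 is therefore estimated at 5800 nM, with a likely range from 3000 nM to 11000 nM.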

Compound 4, half-maximal inhibitory concentration: 4300 nM
Compound 4: the middle estimate sits 1.3-fold (0.13 log units) above what was measured, and the stated range covers the measured number.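

In this assay, 4-bromophenyl in place of 3-bromophenyl gave a 1.2-fold lower number from compound 3 to compound 4 (0.08 log units; within the scatter), so on the core of compound 3 the change again left the number within the scatter. The change carried across the two cores without a readable difference: the same change on two cores in this assay, a 1.1-fold higher number (0.05 log units; within the scatter) from compound 1 to compound 2 and a 1.2-fold lower number (0.08 log units; within the scatter) from compound 3 to compound 4, 1.4-fold (0.13 log units) apart, within the scatter of two such steps. Among the compounds shown here, this shows only that the swap makes no readable difference on these two cores in this one cell assay; it does not show that this would hold on any further core, and it gives no reason for the result.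

All four compounds carry bromine and methoxy groups. From the compounds shown here alone, whether the result would hold with a chlorine, a nitrile or an amine in place of the bromine, or with a hydroxyl in place of the methoxy groups, stays open.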